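The compounds below may be only part of what the source reports. "The series", "measured", "known", "first", "only" and "open" are said of these compounds alone.

Measured compounds in an ADME assay on MT4 cells (Homo sapiens) for cytotoxicity, read by MTT assay; a lower number here means that less compound is tolerated, a higher number that more compound is tolerated:

compound 1, `COc1ccc(CNC(=O)c2[nH]c3ccc(Cl)cc3c2S(=O)(=O)c2cc(C)cc(C)c2)cc1`, which in this assay gives 39900 nM.
compound 2, `Cc1cc(C)cc(S(=O)(=O)c2c(C(=O)NCc3ccccc3F)[nH]c3ccc(Cl)cc23)c1`; in this assay compound 2 reaches only a limit, > 53000 nM.
compound 3, `Cc1cc(C)cc(S(=O)(=O)c2c(C(=O)NCc3ccc(F)cc3)[nH]c3ccc(Cl)cc23)c1`; in this assay compound 3 likewise reaches only a limit, > 53000 nM.

Compound 3 therefore stands at the limit of > 53000 nM in this assay, at which 2 of the 3 values shown sit, with no number of its own. Compound 4, `Cc1cc(C)cc(S(=O)(=O)c2c(C(=O)NCc3ccc([N+](=O)[O-])cc3)[nH]c3ccc(Cl)cc23)c1`, differs from it in one place: nitro in place of fluoro on an aromatic carbon. Among the measured compounds shown here, the steps that bear on this position are an at least 1.3-fold higher number from compound 1 to compound 3 (0.12 log units; that floor lies within the scatter) and a step that the two limits leave unreadable from compound 2 to compound 3, both ending at the limit and neither readable in size. As far as these compounds go, none of the three compounds carries a nitro group, so the change itself is untested. The account expects an at least 1.0-fold lower number from compound 3 to compound 4 (0.02 log units; that floor lies within the scatter), nothing beyond the scatter; compound 4 is estimated at 50000 nM, within 25000 nM to 90000 nM.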

Compound 4, half-maximal cytotoxic concentration: > 50200 nM
Compound 4: only a limit was reported; the forecaster's own chance of this, stated with the estimate: 55%; middle value at least 1.0-fold (0.00 log units) away from the limit.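

With nitro in place of fluoro on the aromatic carbon, compound 4 also gives no number of its own in this assay, only a limit: the limit of > 50200 nM in this assay, at which 1 of the 4 values shown sits. The nitro group, the largest of the groups tried at this place by heavy atoms, therefore joins fluoro at a limit. Against compound 1, the only compound with a number, the change reads as an at least 1.2-fold higher number from compound 1 to compound 4 (0.09 log units; that floor lies within the scatter), while the steps among compound 2, compound 3 and compound 4 cannot be read.

As far as these compounds go, how far each of these three lies past its limit stays open, so the 4-fluorobenzyl and 4-nitrobenzyl groups cannot be ranked. From the compounds shown here alone, whether an amine or a carboxylic acid at this place would give a number in this assay also stays open.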